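Aryl ether swap across two drawn configurations

The source may hold more compounds than are shown below. What is called first, only, known or untested is meant among the compounds shown, and "the series" means these compounds.

Compound 1 `C=C1CC[C@@H]2[C@](C)(CO)[C@H](O)CC[C@@]2(C)[C@@H]1C/C=C1/C(=O)OC[C@@H]1Oc1cccc2ccc(C)nc12` in an ADME assay on Vero cells (Chlorocebus sabaeus) for cytotoxicity, read by MTT assay, with a stated time of 48 h (on this read-out lower numbers stand for higher toxicity in this test and higher numbers for lower toxicity in this test), gives 99800 nM. Compound 2 `C=C1CC[C@@H]2[C@](C)(CO)[C@H](O)CC[C@@]2(C)[C@@H]1C/C=C1/C(=O)OC[C@@H]1Oc1ccnc2ccccc12` gives 20700 nM in this assay. Compound 3 `C=C1CC[C@@H]2[C@](C)(CO)[C@H](O)CC[C@@]2(C)[C@@H]1C/C=C1/C(=O)OC[C@H]1Oc1cccc2ccc(C)nc12` gives 61400 nM in this assay. Compound 3 relates to compound 1 by the two compounds have the same atoms and bonds and differ only in configuration as drawn: 1 of 7 stereo elements differ; a stereocentre at a saturated ring carbon is drawn R in compound 1 and S in compound 3; the step of a 1.6-fold lower number from compound 1 to compound 3 (0.21 log units; within the scatter) stays within the scatter, consistent with the fact that compounds 1 and 3 differ only in the configuration as drawn. The change quinolin-4-yl in place of 2-methylquinolin-8-yl on an oxygen on a saturated carbon produced a 4.8-fold lower number from compound 1 to compound 2 (0.68 log units; beyond the scatter), a modest step beyond the scatter. Compound 4 `C=C1CC[C@@H]2[C@](C)(CO)[C@H](O)CC[C@@]2(C)[C@@H]1C/C=C1/C(=O)OC[C@H]1Oc1ccnc2ccccc12`, not yet measured, carries the same change on compound 3, namely (quinolin-4-yl in place of 2-methylquinolin-8-yl on an oxygen on a saturated carbon); the place is described in the same words in both pairs, so it is the same change on the other drawn configuration. Resting on a 4.8-fold lower number from compound 1 to compound 2 (0.68 log units; beyond the scatter) as the single precedent, the step in this assay is expected to come out near a 4.8-fold lower number from compound 3 to compound 4 (0.68 log units; beyond the scatter). Compound 4 is therefore estimated at 12800 nM, with a likely range from 5500 nM to 30000 nM.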

Compound 4, half-maximal cytotoxic concentration: 22800 nM
The estimate for compound 4 lay 1.8-fold (0.25 log units) below the measured number; the range from low to high includes it.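

In this assay the swap to quinolin-4-yl repeats on the other drawn configuration, giving a 2.7-fold lower number from compound 3 to compound 4 (0.43 log units; beyond the scatter), and the two steps agree: the same change on two cores in this assay, a 4.8-fold lower number (0.68 log units; beyond the scatter) from compound 1 to compound 2 and a 2.7-fold lower number (0.43 log units; beyond the scatter) from compound 3 to compound 4, 1.8-fold (0.25 log units) apart, within the scatter of two such steps. A step of a 1.1-fold higher number from compound 2 to compound 4 (0.04 log units; within the scatter) stays within the scatter, in keeping with: the fact that compounds 2 and 4 differ only in the configuration as drawn. This shows the change carrying over between two cores that differ at a single stereocentre, but it does not show that it would carry over to a core differing in any other way.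

On these data alone, it remains open how the number moves when phenyl, or a chain ending in an amine or a carboxylic acid, takes the place of quinolin-4-yl on that oxygen. As far as these compounds go, it also remains open how much of the step belongs to the methyl group and how much to the place where the quinoline is attached.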